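From Acetyl to Propanoyl in a Mouse Assay

A few compounds are considered here, and "the series" means these few. Any claim that something is new, unique, unknown or untested is made for them only; others in the source may bear on it.

Compound 1 `CC(=O)N1CCCN(S(=O)(=O)c2ccc(F)cc2)CC1`: 1 mg/kg
Compound 2 `CCCS(=O)(=O)N1CCCN(C(C)=O)CC1`: a limit of the assay, > 10 mg/kg
Compound 3 `CC(=O)N1CCN(S(=O)(=O)c2ccc(F)cc2)C1`: 1 mg/kg

In a functional assay on the whole organism with Mus musculus as the target (on this read-out lower numbers stand for an effect already at smaller amounts and higher numbers for an effect only at larger amounts of compound), compound 3 stands level with compound 1 at the digits shown, a difference within the usual scatter. For compound 2 the reading is only the limit of > 10 mg/kg in this assay, at which 1 of the 3 values shown sits, and not a number. Compound 4 `CCC(=O)N1CCN(S(=O)(=O)c2ccc(F)cc2)C1` has not yet been measured; it differs from compound 3 by methyl in place of hydrogen on a saturated chain carbon bound to a carbonyl carbon. Going by the values given here, no measured pair differs in just this place, so the step is judged from the size of the change alone: a small one, expected to stay within the scatter, with no clear direction. Compound 4 is therefore expected to give about 1 mg/kg, most likely between 0.3 mg/kg and 3 mg/kg. The expected step is no change at the digits printed from compound 3 to compound 4 (within the scatter).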

Compound 4, minimum effective dose: 1 mg/kg
Compound 4: the middle estimate sits on the measured number at the digits printed, and the stated range covers the measured number.
By their numbers in this assay, from the lowest: compounds 1, 3 and 4 (each within the scatter of the next). At a limit, above all of these: compound 2.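

Going from acetyl to propanoyl gives no change at the digits printed from compound 3 to compound 4 (within the scatter) in this assay, the first view of this place on the molecule. Going by these compounds alone, a methyl in place of hydrogen on a saturated chain carbon bound to a carbonyl carbon is thus tolerated in this read-out, something the earlier compounds, all acetyl, could not show. Nothing among the values shown explains this reading.

From the compounds shown here alone, whether a longer chain such as butanoyl would read the same remains open. So does the outcome with an amine or a carboxylic acid at this place.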